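The source may hold more compounds than are shown below. What is called first, only, known or untested is meant among the compounds shown, and "the series" means these compounds.

Compound 1 `Nc1ccccc1NC(=O)c1ccc(CSC(=S)N2CCN(c3ccc(Cl)cc3)CC2)cc1`: 17.2%
Compound 2 `Nc1ccccc1NC(=O)c1ccc(CSC(=S)N2CCc3ccccc32)cc1`: 87%
Compound 3 `Cc1ccc(N2CCN(C(=S)SCc3ccc(C(=O)Nc4ccccc4N)cc3)CC2)cc1`: 19.8%

In a functional assay on MGC-803 cells (Homo sapiens) for antiproliferative activity, read by CCK-8 assay, with a stated time of 72 h, tested at 8 uM (on this read-out higher numbers stand for a stronger effect at the one concentration tested and lower numbers for a weaker effect), compound 2 gives 87%, the highest of the three numbers and well beyond the usual scatter from both others. In this assay compound 1 gives 17.2% and compound 3 gives 19.8%. For the measured compounds named here, the only measured step between two compounds that differ in one place is a number 2.6 percentage points higher from compound 1 to compound 3 (within the scatter), which lies within the scatter and so says nothing about direction.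

Compound 4 `CN1CCN(C(=S)SCc2ccc(C(=O)Nc3ccccc3N)cc2)CC1` differs from compound 2 in one place: 4-methylpiperazin-1-yl in place of 2,3-dihydro-1H-indol-1-yl on a thiocarbonyl carbon. Going by the values given here, no measured step covers this kind of change, so the expectation rests on the plain pattern among the three numbers: the one compound that carries the 2,3-dihydro-1H-indol-1-yl group, compound 2, gives a high number, while compound 1 and compound 3, which lack it, both give low numbers. Removing that group therefore points to a drop in this assay, beyond the scatter, though how far is uncertain. For compound 4 the expected step is a number 52 percentage points lower from compound 2 to compound 4 (beyond the scatter). Compound 4 is thus estimated at 35%, with a range from 10% to 70%.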

Compound 4, a percentage reported as inhibition, at one concentration (the size of the read-out at that concentration, not a potency): 84.4%
Estimate against measurement, compound 4: 49.4 percentage points below; the measured number lies above the stated range.
By their numbers in this assay, from the lowest: compounds 1 and 3 (each within the scatter of the next); then compounds 4 and 2 (each within the scatter of the next).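

In this assay, the high number of compound 2 does not depend on the 2,3-dihydro-1H-indol-1-yl group on the thiocarbonyl carbon: a number 2.6 percentage points lower from compound 2 to compound 4 (within the scatter), so 4-methylpiperazin-1-yl can stand at this place with no difference beyond the scatter. Compound 1, compound 3 and compound 4 differ from each other in the group on the amine nitrogen in the ring. This group therefore comes into focus, with a number 64.6 percentage points higher from compound 3 to compound 4 (beyond the scatter) and a number 67.2 percentage points higher from compound 1 to compound 4 (beyond the scatter). Among these three compounds, methyl on that nitrogen goes with a high number, while 4-methylphenyl and 4-chlorophenyl each go with a low number, and none of the three goes against this pattern.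

From the compounds shown here alone, it remains open where the number falls between methyl and the two substituted phenyl rings, for instance with ethyl, a longer chain or benzyl on that nitrogen, and whether compound 2 and compound 4 would also stay within the scatter of each other at other concentrations. Nothing available here gives a reason for the large steps or for the near match.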